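A few compounds are considered here, and "the series" means these few. Any claim that something is new, unique, unknown or untested is made for them only; others in the source may bear on it.

Compound 1 `O=C(Nc1cc(C(F)(F)F)ccc1Nc1ccc(Br)cc1)c1cccnc1Cl` and compound 2 `O=C(Nc1cc(C(F)(F)F)ccc1Nc1ccc(Br)cc1)c1ccccc1` share a core and differ only in the ring on the carbonyl carbon. In a functional assay on NALM-6 cells (Homo sapiens) for cytotoxicity, read by MTT assay, with a stated time of 48 h (a lower number here means a stronger inhibitor, a higher number a weaker inhibitor), compound 1 gives 35700 nM, the highest of the two numbers in hand, and compound 2 gives 6000 nM. Going by the values given here, the one measured step, a 6.0-fold lower number from compound 1 to compound 2 (0.77 log units; beyond the scatter), concerns the carbonyl side alone.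

Compound 3 `CCN(CC)c1ccc(C(F)(F)F)cc1NC(=O)c1cccnc1Cl` keeps the 2-chloropyridin-3-yl group of compound 1 and changes the other side: diethylamino in place of (4-bromophenyl)amino on an aromatic carbon. Among the compounds with values here, no measured step touches this position, so the step from compound 1 to compound 2 gives no direct guide to it, and the expectation must lean on compound 1 alone. Compound 3 is therefore estimated to stay near compound 1, with a 1.1-fold higher number from compound 1 to compound 3 (0.05 log units; within the scatter), not beyond the scatter. For compound 3 the expected value in this assay is 40000 nM, within a range from 10000 nM to 150000 nM.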

Compound 3, half-maximal inhibitory concentration: "not active" (no number reported)
Compound 3 has no reported number here, so the estimate cannot be set against anything.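

Going by these compounds alone, compound 3 is reported in this assay as not active, with no number, so no step from compound 1 to compound 3 can be read, and no measurement at hand bears on this result. The compounds shown leave open how far diethylamino in place of (4-bromophenyl)amino shifts the number.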